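The source may report more compounds than this note shows. Statements on the series, on what has been measured and on what is new or still open speak of the compounds shown alone.

Measured compounds:
- compound 1, `[O-][S+](CCNC1CCN(Cc2ccc(F)cc2)CC1)C(c1ccc(F)cc1)c1ccc(F)cc1`, 50.6 nM
- compound 2, `Fc1ccc(C(SCCNC2CCN(Cc3cc4ccccc4o3)CC2)c2ccc(F)cc2)cc1`, 120 nM
- compound 3, `CC(C)(C)C(=O)N1CCC(NCCSC(c2ccc(F)cc2)c2ccc(F)cc2)CC1`, 352 nM

In an assay on membranes from striatum (strain Sprague-Dawley) for displacement of a labelled ligand from sodium-dependent dopamine transporter (Rattus norvegicus), read by scintillation counting, with a stated time of 120 min (on this read-out lower numbers stand for stronger inhibition and higher numbers for weaker inhibition), compound 1 gives 50.6 nM, the lowest of the three numbers; compound 2 gives 120 nM and compound 3 gives 352 nM. Among the compounds with values here, the one single-point step among the measured compounds is a 2.9-fold higher number from compound 2 to compound 3 (0.47 log units; beyond the scatter), a change of the group on the amine nitrogen in the ring from an arylmethyl to an acyl group.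

Compound 4, `O=C(c1ccccc1F)N1CCC(NCC[S+]([O-])C(c2ccc(F)cc2)c2ccc(F)cc2)CC1`, is not yet measured. It differs from compound 1 in one place: (2-fluorophenyl)carbonyl in place of 4-fluorobenzyl on an amine nitrogen in a ring. Like the step from compound 2 to compound 3, this exchanges an arylmethyl on the ring nitrogen for a carbonyl-bearing group, so that step is the only one that bears on it. On that basis the number for compound 4 is expected to move upward beyond the scatter, by a modest amount, a 3.0-fold higher number from compound 1 to compound 4 (0.47 log units; beyond the scatter). The estimate for compound 4 in this assay is therefore 150 nM, within a range from 60 nM to 400 nM.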

Compound 4, inhibition constant: 604 nM
Beside the measured number, compound 4's estimate is 4.0-fold (0.60 log units) below it; measured number outside the range, above it.
By their numbers in this assay, from the lowest: compound 1; then compound 2; then compounds 3 and 4 (each within the scatter of the next).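

In this assay, the exchange on this ring nitrogen weighs more heavily in the core of compound 1 than the earlier step suggested: there is a 12-fold higher number from compound 1 to compound 4 (1.08 log units; beyond the scatter), against a 2.9-fold higher number from compound 2 to compound 3 (0.47 log units; beyond the scatter). Both the leaving and the entering group carry one six-membered aromatic ring of carbon only, so such a ring on this nitrogen does not by itself hold the number down, and the counted differences are the added carbonyl double bond and its hydrogen-bond acceptor. No measurement at hand explains the size of this step.

The compounds shown do not separate the effect of the carbonyl from that of moving the fluorine, which a 2-fluorobenzyl group on the same nitrogen would address. Going by these compounds, how a sulfonyl link or an unsubstituted benzyl group would read at this position also remains open.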